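Adding a Third Methoxy to a Dihydropyranone Styryl Scaffold

The source may hold more compounds than are shown below. What is called first, only, known or untested is meant among the compounds shown, and "the series" means these compounds.

Compound 1 `O=c1ccoc(/C=C/c2ccccc2)c1` gives 711 uM in an ADME assay on HaCaT cells (Homo sapiens) for inhibition, read by sulforhodamine B assay, with a stated time of 48 h; on this read-out lower numbers stand for stronger inhibition of growth and higher numbers for weaker inhibition of growth. Compound 2 `COc1ccc(/C=C/c2cc(=O)cco2)cc1` differs from it by methoxy in place of hydrogen on an aromatic carbon and gives 710 uM in this assay, a step of a 1.0-fold lower number from compound 1 to compound 2 (0.00 log units; within the scatter). Compound 3 `COc1cc(/C=C/C2CC=CC(=O)O2)cc(OC)c1` is built on a different core; the difference between the two cores is not broken down here. In this assay compound 3 gives 8.8 uM, the lowest of the three numbers. Compound 4 `COc1cc(/C=C/C2CC=CC(=O)O2)cc(OC)c1OC` differs from compound 3 by methoxy in place of hydrogen on an aromatic carbon, the same kind of change as from compound 1 to compound 2, though here the entering group sits ortho to two methoxy groups. Because a 1.0-fold lower number from compound 1 to compound 2 (0.00 log units; within the scatter) lay within the scatter, the expected step of a 1.0-fold higher number from compound 3 to compound 4 (0.01 log units; within the scatter) is likewise small. Compound 4 is therefore expected to give about 9 uM in this assay, between 3 uM and 27 uM.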

Compound 4, concentration for growth inhibition (reported as GI): 21.6 uM
Compound 4: the middle estimate sits 2.4-fold (0.38 log units) below what was measured; the range from low to high includes it.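

In this assay, the methoxy entering ortho to two methoxy groups gives a 2.5-fold higher number from compound 3 to compound 4 (0.39 log units; beyond the scatter), a modest step. Set beside the earlier step, the same change on the two cores does not separate: the same change on two cores in this assay, a 1.0-fold lower number (0.00 log units; within the scatter) from compound 1 to compound 2 and a 2.5-fold higher number (0.39 log units; beyond the scatter) from compound 3 to compound 4, 2.5-fold (0.39 log units) apart, within the scatter of two such steps. The change can therefore be said to carry across only in the sense that the two steps cannot be told apart; with one pair on each core, and the entering group ortho to two methoxy groups only in compound 4, this does not show that it behaves alike on both cores.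

The compounds shown leave open how an amine, a carboxylic acid or a longer chain would fare at this place on compound 3. They also leave open what methoxy would do on the core of compound 1 if it entered ortho to two methoxy groups.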